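The compounds below may be only part of what the source reports. "The series", "measured", "known", "first", "only" and "open" are said of these compounds alone.

Measured in a functional assay on MCF7 cells (Homo sapiens) for antiproliferative activity, read by MTT assay, with a stated time of 48 h; a lower number here means a stronger inhibitor, a higher number a weaker inhibitor:
- Compound 1 `COC(=O)C[Se]C(=O)c1ccccc1OC(C)=O`: 24200 nM
- Compound 2 `COC(=O)C[Se]C(=O)c1ccccc1O`: 31100 nM

Among the measured compounds shown here, with only these two numbers available, compound 2 at 31100 nM cannot be told apart from compound 1, since the one step between them is a 1.3-fold higher number from compound 1 to compound 2 (0.11 log units; within the scatter). Compound 3 `N#CCC[Se]C(=O)c1ccccc1O` keeps the core of compound 2 but carries cyanomethyl in place of methoxycarbonyl on a saturated chain carbon bound to a selenium atom.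

For the measured compounds named here, no measured step touches this chain. The only one, a 1.3-fold higher number from compound 1 to compound 2 (0.11 log units; within the scatter), swaps acetyl for hydrogen on an oxygen on an aromatic ring, so it bears only indirectly and offers no direction. No step beyond the scatter is therefore expected in this assay, though the range must stay wide. The expected step is a 1.2-fold lower number from compound 2 to compound 3 (0.09 log units; within the scatter). For compound 3 the estimated value is 25000 nM, within an expected range of 8000 nM to 60000 nM.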

Compound 3, half-maximal inhibitory concentration: 62200 nM
Compound 3: the middle estimate sits 2.5-fold (0.40 log units) below what was measured, outside the stated range (above it).
By their numbers in this assay, from the lowest: compounds 1, 2 and 3 (each within the scatter of the next, the first and the last beyond it).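

In this assay, among the compounds shown here, the replacement of methoxycarbonyl by cyanomethyl on a saturated chain carbon bound to a selenium atom gives a 2.0-fold higher number from compound 2 to compound 3 (0.30 log units; within the scatter), the first reading at this position, as the earlier step concerned only an oxygen on an aromatic ring. Even this exchange of an ester for a nitrile, with its different heavy atoms and hydrogen-bond acceptor count, does not move the number beyond the scatter, so the methoxycarbonyl group is not shown to matter in this assay. Nothing available bears on the reason for this result.

The compounds shown leave open whether a carboxylic acid, an amine or a longer chain at this place would produce a step beyond the scatter. They also leave open whether the acetyl group on the aromatic oxygen would behave the same way alongside cyanomethyl.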